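Aryl swap on the pyridazinone nitrogen at the cytotoxicity limit

A few compounds are considered here, and "the series" means these few. Any claim that something is new, unique, unknown or untested is made for them only; others in the source may bear on it.

Working notes on the series. Compound 1 `Cc1cc(=O)n(-c2cccc(F)c2)nc1C(=O)Nc1ccc(Oc2ncnc3c2ccn3C)cc1` sits at the limit in a functional assay on HepG2 cells (Homo sapiens) for cytotoxicity, read by MTT assay, with a stated time of 72 h (on this read-out higher numbers stand for weaker inhibition and lower numbers for stronger inhibition), giving > 60000 nM. Compound 2 `Cc1cc(=O)n(-c2ccc(Br)cc2F)nc1C(=O)Nc1ccc(Oc2ncnc3c2ccn3C)c(F)c1` also sits at the limit in this assay, giving > 60000 nM. Both values are limits, (the limit of > 60000 nM in this assay, at which 2 of the 2 values shown sit), and no number is known for either. Compound 3 `Cc1cc(=O)n(-c2cccc(F)c2)nc1C(=O)Nc1ccc(Oc2ncnc3c2ccn3C)c(F)c1` differs from compound 2 by 3-fluorophenyl in place of 4-bromo-2-fluorophenyl on an aromatic nitrogen. With compound 1 and compound 2 both at the limit, no step beyond the usual scatter is expected, and the estimated step is a step that the limit leaves unreadable from compound 2 to compound 3. Compound 3 is expected to give about 90000 nM, within 30000 nM to 300000 nM, most likely as a limit again.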

Compound 3, half-maximal inhibitory concentration: > 60000 nM
Compound 3 gave a limit, no number (the forecaster's own chance of this, stated with the estimate: 85%); the middle value does not contradict the limit.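

Compound 3 joins compound 1 and compound 2 at the limit, so neither step to compound 3 can be read in this assay: the limit of > 60000 nM in this assay, at which 3 of the 3 values shown sit. The compounds shown leave open whether the aryl swap or the added fluoro changes cytotoxicity at all.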